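The source may hold more compounds than are shown below. What is called first, only, known or untested is meant among the compounds shown, and "the series" means these compounds.

Three compounds that share one core were measured in a physicochemical assay for solubility, read by HPLC, measured as thermodynamic solubility, with a stated time of 4 h, at pH 6.8; on this read-out higher numbers stand for higher solubility and lower numbers for lower solubility. Compound 1 `Cn1c(COc2cccc(C(=O)O)c2)nc2ccc(Oc3ccc(Cl)cn3)cc21` gave 17 ug/mL in this assay. Compound 2 `Cn1c(COc2cccc(C(=O)O)c2)nc2ccc(Oc3ccc(F)cn3)cc21` differs from compound 1 by fluoro in place of chloro on an aromatic carbon, and in this assay compound 2 gave 79 ug/mL; this exchange produced a 4.6-fold higher number from compound 1 to compound 2 (0.67 log units; beyond the scatter). Compound 3 `Cn1c(COc2cccc(C(=O)O)c2)nc2ccc(Oc3ncc(Cl)cc3Cl)cc21` carries a different core, set apart from the core of compound 1 by chloro in place of hydrogen on an aromatic carbon. In this assay compound 3 gave 9.9 ug/mL, which amounts to a 1.7-fold lower number from compound 1 to compound 3 (0.23 log units; within the scatter) and to an 8.0-fold lower number from compound 2 to compound 3 (0.90 log units; beyond the scatter).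

Compound 4 `Cn1c(COc2cccc(C(=O)O)c2)nc2ccc(Oc3ncc(Cl)cc3F)cc21` has not yet been measured. It differs from compound 3 by fluoro in place of chloro on an aromatic carbon. This is the same kind of change as that made from compound 1 to compound 2, but not the same one: in compound 1 the exchanged atom sits para to a large group, whereas in compound 3 it sits ortho to a large group and meta to a chloro group. Because a 4.6-fold higher number from compound 1 to compound 2 (0.67 log units; beyond the scatter) lies beyond the scatter, a step in the same direction is expected for compound 4, although the different surroundings leave it open whether the step will match in size, and only one measured example of this kind of change exists among these compounds. Compound 4 is therefore expected to show a 3.0-fold higher number from compound 3 to compound 4 (0.48 log units; beyond the scatter) in this assay. The estimate for compound 4 in this assay is 30 ug/mL, with a likely range from 12 ug/mL to 70 ug/mL.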

Compound 4, solubility: 10 ug/mL
Compound 4: the middle estimate sits 3.0-fold (0.48 log units) above what was measured; measured number outside the range, below it.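

In this assay fluoro in place of chloro on an aromatic carbon gave a 4.6-fold higher number from compound 1 to compound 2 (0.67 log units; beyond the scatter) on the core of compound 1 but a 1.0-fold higher number from compound 3 to compound 4 (0.00 log units; within the scatter) on the core of compound 3, so the step did not carry from one core to the other at the place in compound 3 that is ortho to a large group and meta to a chloro group. The other two new steps fit this reading, since a 7.9-fold lower number from compound 2 to compound 4 (0.90 log units; beyond the scatter) marks compound 2 as apart, whereas a 1.7-fold lower number from compound 1 to compound 4 (0.23 log units; within the scatter) leaves compound 4 indistinguishable from compound 1 in this read-out. With one pair on each core, this does not show how the exchange would behave on any further core, and nothing available explains why the two pairs part ways.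

The compounds shown leave open whether 3,5-difluoropyridin-2-yl on the same oxygen would reach the number of compound 2, which gave 79 ug/mL in this assay, or would stay with compound 3 and compound 4. They also leave open how a methoxy group or a nitrile on that aromatic carbon would read, and whether an amine in place of the carboxylic acid would change the picture on either core.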